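The compounds below may be only part of what the source reports. "The series", "measured", "known", "first", "only" and "open" are said of these compounds alone.

Measured in a functional assay on SK-OV-3 cells (Homo sapiens) for cytotoxicity; on this read-out higher numbers stand for weaker inhibition and lower numbers for stronger inhibition:
- compound 1 `Cc1ccc2c(N3CCN(C)CC3)nc(-c3ccc(Cl)cc3)cc2c1`: 5750 nM
- compound 2 `Cc1ccc(-c2cc3cc(C)ccc3c(N3CCN(C)CC3)n2)cc1`: 7080 nM

In this assay compound 2 stands at 7080 nM, within the scatter of compound 1. Compound 3 `Cc1ccc2c(N3CCN(C)CC3)nc(-c3ccccc3C)cc2c1` keeps the shared core but carries 2-methylphenyl in place of 4-methylphenyl on an aromatic carbon. Within the data shown here, the only measured step is a 1.2-fold higher number from compound 1 to compound 2 (0.09 log units; within the scatter), with methyl in place of chloro on an aromatic carbon. That step leaves the methyl where it is, so it bears on this change only loosely, and the range stays wide. The estimated change is a 1.1-fold lower number from compound 2 to compound 3 (0.04 log units; within the scatter), so no step beyond the scatter is expected. For compound 3 the expected value is 6500 nM, with an estimated range of 2500 nM to 16000 nM.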

Compound 3, half-maximal inhibitory concentration: 5130 nM
Compound 3: middle estimate off by 1.3-fold (0.10 log units), on the high side; low and high end bracket the measured number.
By their numbers in this assay, from the lowest: compounds 3, 1 and 2 (each within the scatter of the next).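

In this assay, 2-methylphenyl in place of 4-methylphenyl gives a 1.4-fold lower number from compound 2 to compound 3 (0.14 log units; within the scatter) within the scatter, so this pair tests where the methyl sits on the aryl group, which the earlier step did not, and the number does not separate the two. Against the 4-chlorophenyl of compound 1, the same group gives a 1.1-fold lower number from compound 1 to compound 3 (0.05 log units; within the scatter) and is also within the scatter. Nothing measured here offers an explanation for these results. On these data alone, what remains open is whether an amine or a carboxylic acid on this phenyl ring would give a step beyond the scatter.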